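The source may hold more compounds than are shown below. What is called first, only, known or untested is meant among the compounds shown, and "the series" means these compounds.

Among the compounds with values here, compound 1 `CN(Cc1ccccc1)C(=O)c1sc(-c2ccc(S(C)(=O)=O)c([N+](=O)[O-])c2)nc1C(F)(F)F` is the stronger of the two compounds measured so far in a functional assay for antagonist activity at thyroid hormone receptor alpha (Homo sapiens), read by fluorescence polarization; a lower number here means a stronger inhibitor, a higher number a weaker inhibitor: in this assay compound 1 gives 460 nM. Compound 2 `Cc1nc(-c2ccc(S(C)(=O)=O)c([N+](=O)[O-])c2)sc1C(=O)N1CCC(C)CC1` differs from compound 1 in several spots at once. In this assay compound 2 gives 5600 nM, a considerably higher number, but since the two structures differ in several places, no single change can be credited with that gap.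

Compound 3 `CC1(C)CC2CC(C)(CN2C(=O)c2sc(-c3ccc(S(C)(=O)=O)c([N+](=O)[O-])c3)nc2C(F)(F)F)C1` has not yet been measured. It keeps the core of compound 1 and changes only the group on the carbonyl carbon: a group of 11 heavy atoms (10 carbon, 1 nitrogen; one five-membered non-aromatic ring with 1 hetero atom, one six-membered non-aromatic ring of carbon only) in place of a group of 9 heavy atoms (8 carbon, 1 nitrogen; one six-membered aromatic ring of carbon only), on a carbonyl carbon

Within the data shown here, no measured pair shows this kind of exchange on its own, so the size of the step is uncertain. Among the measured compounds shown here, the only hint is that compound 2, which also carries a non-aromatic amine on the carbonyl carbon, gives 5600 nM, a weaker result; but compound 2 differs in another place too. A modest loss in this assay is therefore expected for compound 3, and the step of a 2.0-fold higher number from compound 1 to compound 3 (0.29 log units; within the scatter) is the estimated outcome. Compound 3 is expected to give about 900 nM, most likely between 250 nM and 4000 nM.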

Compound 3, half-maximal inhibitory concentration: 430 nM
For compound 3 the middle estimate is 2.1-fold (0.32 log units) above the measured one, and the stated range covers the measured number.
By their numbers in this assay, from the lowest: compounds 3 and 1 (each within the scatter of the next); then compound 2.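

The exchange on the carbonyl carbon in this assay gives a 1.1-fold lower number from compound 1 to compound 3 (0.03 log units; within the scatter), so the two compounds cannot be told apart in this assay. With the rest of compound 1 kept unchanged, the benzyl(methyl)amino group and its six-membered aromatic ring can therefore give way to a group whose two rings are both non-aromatic, with no loss that this assay can detect. This is a single pair, so it shows that an aromatic ring is not needed on this carbonyl carbon in this one setting, not that every non-aromatic amine group would do as well.

The compounds shown leave open how far this tolerance extends, for example to a morpholine ring, which brings an oxygen atom into the group, or to a small dimethylamino group on the same carbonyl carbon. Within the data shown here, they also do not separate the effect of the amine group from that of swapping trifluoromethyl for methyl, since no pair here changes either one alone. Nothing available here bears on why the two groups give such similar numbers.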